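Naphthalen-1-yl for cyclohexyl: expected cytotoxicity of compound 4

A few compounds are considered here, and "the series" means these few. Any claim that something is new, unique, unknown or untested is made for them only; others in the source may bear on it.

Compound 1 `O=C1c2ccccc2N(Cc2ccccc2Cl)S(=O)(=O)N1Cc1ccccc1`: in a functional assay on MRC5 cells (Homo sapiens) (on this read-out higher numbers stand for lower toxicity in this test and lower numbers for higher toxicity in this test), compound 1 gives 60000 nM.
Compound 2 `O=C1c2ccccc2N(Cc2cccc(Cl)c2)S(=O)(=O)N1Cc1ccccc1`: in this assay compound 2 gives 60000 nM.
Compound 3 `O=C1c2ccccc2N(CC2CCCCC2)S(=O)(=O)N1Cc1ccccc1`: in this assay compound 3 reaches only a limit, > 65000 nM.

Compound 3 thus stands at the edge of the numbers shown: for it only a limit is known (the limit of > 65000 nM in this assay, at which 1 of the 3 values shown sits), and the steps of an at least 1.0-fold higher number from compound 1 to compound 3 (0.03 log units; that floor lies within the scatter) and an at least 1.0-fold higher number from compound 2 to compound 3 (0.03 log units; that floor lies within the scatter) are floors that lie within the scatter, as does no change at the digits printed from compound 1 to compound 2 (within the scatter). Compound 4 `O=C1c2ccccc2N(Cc2cccc3ccccc23)S(=O)(=O)N1Cc1ccccc1` differs from compound 3 by naphthalen-1-yl in place of cyclohexyl on a saturated chain carbon bound to a sulfonamide nitrogen in a ring. Among the measured compounds shown here, no measured step exchanges this group for one of two six-membered aromatic rings, but the three steps among compounds 1, 2 and 3 show the read-out little moved by the group at this place. No step beyond the scatter is therefore expected in this assay, and the expected step of an at least 1.0-fold lower number from compound 3 to compound 4 (0.03 log units; that floor lies within the scatter) reflects this. Compound 4 is estimated at 60000 nM, ranging from 25000 nM to 130000 nM.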

Compound 4, half-maximal cytotoxic concentration: > 58000 nM
Compound 4 ended at the assay's limit; the forecaster's own chance of this, stated with the estimate: 50%; the middle value is on the limit's open side.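

In this assay compound 4 reaches only a limit, > 58000 nM. Its steps from compound 1, compound 2 and compound 3 cannot be read. As far as these compounds go, whether naphthalen-1-yl at this place shifts the read-out at all stays open.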